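Cutting the amide substituent of compound 1 to methyl

The compounds below may be only part of what the source reports. "The series", "measured", "known", "first", "only" and "open" are said of these compounds alone.

Going by the values given here, in a functional assay on MIA PaCa-2 cells (Homo sapiens) for inhibition, read by MTT assay, with a stated time of 3 days (on this read-out higher numbers stand for weaker inhibition and lower numbers for stronger inhibition), compound 1 (`CCN(CC)S(=O)(=O)c1ccc(S(=O)(=O)N2CCC[C@@H](C(=O)N[C@@H]3CCN(C(=O)OC(C)(C)C)C3)C2)cc1`) gives 500 nM, the higher of the two numbers so far. Compound 2 (`CCN(CC)S(=O)(=O)c1ccc(S(=O)(=O)N2CCC[C@@H](C(=O)N3CCC(c4nc(C(C)C)no4)CC3)C2)cc1`) gives 30 nM, and that gap lies beyond the scatter.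

Compound 3 (`CCN(CC)S(=O)(=O)c1ccc(S(=O)(=O)N2CCC[C@@H](C(=O)NC)C2)cc1`) keeps the core of compound 1 and carries methyl in place of 1-(tert-butoxycarbonyl)pyrrolidin-3-yl on an amide-type nitrogen. Among the compounds with values here, no measured pair isolates this change, so the expectation rests on thin ground: neither measured compound has so small a group on the amide side, and a loss of inhibition seems more likely than a gain. In this assay the expected change is a moderate move towards a higher number, beyond the scatter, estimated as a 6.0-fold higher number from compound 1 to compound 3 (0.78 log units; beyond the scatter). For compound 3 the estimated value is 3000 nM, with an expected range of 800 nM to 12000 nM.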

Compound 3, half-maximal inhibitory concentration: 2000 nM
Compound 3: middle estimate off by 1.5-fold (0.18 log units), on the high side; low and high end bracket the measured number.
By their numbers in this assay, from the lowest: compound 2; then compound 1; then compound 3.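

In this assay, going by these compounds alone, methyl in place of 1-(tert-butoxycarbonyl)pyrrolidin-3-yl on the amide-type nitrogen gives a 4.0-fold higher number from compound 1 to compound 3 (0.60 log units; beyond the scatter) and is the first single-place reading. The position therefore responds to its substituent, yet inhibition survives with only methyl there, as compound 3 still gives 2000 nM in this assay. The change removes the ring, the tert-butoxycarbonyl group and a defined stereocentre together, and no data on hand bear on why the number moves.

On these data alone, whether a free pyrrolidin-3-yl amine or a longer alkyl chain on this nitrogen would lie closer to compound 1 or to compound 3 remains open. Compound 2 differs from the other two compounds in more than one place, so steps to it cannot be read.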